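A few compounds are considered here, and "the series" means these few. Any claim that something is new, unique, unknown or untested is made for them only; others in the source may bear on it.

Two heavily acetylated compounds have been tested in a functional assay on HeLa cells (Homo sapiens), read by colorimetric assay, with a stated time of 72 h; on this read-out higher numbers stand for an effect only at larger amounts of compound and lower numbers for an effect already at smaller amounts. Compound 1 `CC(=O)N[C@@H]1[C@@H](OC(C)=O)[C@H](OC(C)=O)[C@@H](COC(C)=O)O[C@H]1n1nncc1CO` reached only a limit of that assay, giving > 100 ug/mL. Compound 2 `CC(=O)OC[C@H]1O[C@@H](n2nnc(CO)c2CO)[C@H](OC(C)=O)[C@@H](OC(C)=O)[C@@H]1OC(C)=O` likewise reached only a limit, giving > 100 ug/mL in this assay. Both measured values sit at the limit of > 100 ug/mL in this assay, at which 2 of the 2 values shown sit. Compound 3 `CC(=O)N[C@@H]1[C@@H](OC(C)=O)[C@H](OC(C)=O)[C@@H](COC(C)=O)O[C@H]1n1nnc(CO)c1CO` differs from compound 2 by acetamido in place of acetoxy on a saturated ring carbon. No step between two measured compounds is shown, so no change beyond the usual scatter is expected from this exchange. Compound 3 is expected to sit at about 100 ug/mL, between 50 ug/mL and 200 ug/mL. The expected step of a number no higher from compound 2 to compound 3 (the limit leaves the size open) stays within the scatter.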

Compound 3, concentration for half-maximal effect: > 100 ug/mL
Compound 3 was reported as a limit; the forecaster's own chance of this, stated with the estimate: 85%; the middle value sits exactly at the limit.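

Among these compounds, compound 1, compound 2 and compound 3 all give only a limit, so no step among them can be read: the limit of > 100 ug/mL in this assay, at which 3 of the 3 values shown sit. The compounds shown leave open whether acetamido in place of acetoxy, or hydroxymethyl in place of hydrogen, changes the effect at all.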